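Urea to Amide: Expectation for Compound 3

A few compounds are considered here, and "the series" means these few. Any claim that something is new, unique, unknown or untested is made for them only; others in the source may bear on it.

Compound 2 `COc1cc(-c2nn(-c3cccc(NC(=O)Nc4cccc(C(F)(F)F)c4)c3)cc2-c2ccncc2)ccc1Cl` gives 1870 nM in a functional assay on HT-29 cells (Homo sapiens) for inhibition, read by sulforhodamine B assay, with a stated time of 48 h (a lower number here means a stronger inhibitor of growth, a higher number a weaker inhibitor of growth), the lowest of the two numbers measured, and the nearest neighbour is compound 1 `COc1cc(-c2nn(-c3cccc(NC(=O)Nc4ccc(Cl)c(Cl)c4)c3)cc2-c2ccncc2)ccc1Cl`, which gives 6460 nM. Compound 3 `COc1cc(-c2nn(-c3cccc(NC(=O)c4ccc(Cl)c(C(F)(F)F)c4)c3)cc2-c2ccncc2)ccc1Cl` has not yet been measured in this assay. It differs from compound 2 by 4-chloro-3-(trifluoromethyl)phenyl in place of (3-(trifluoromethyl)phenyl)amino on a carbonyl carbon. Among the compounds with values here, the only measured step, a 3.5-fold lower number from compound 1 to compound 2 (0.54 log units; beyond the scatter), exchanged one aryl group for another on the urea and bears on compound 3 only loosely, since the change to compound 3 removes an amide-type nitrogen and also brings in chlorine, as in compound 1. Within the data shown here, with no direct precedent, the writer expects compound 3 to land near compound 2, with a step of a 1.3-fold higher number from compound 2 to compound 3 (0.13 log units; within the scatter) that could fall either side of the scatter. The estimated value for compound 3 in this assay is 2500 nM, within a range from 700 nM to 9000 nM.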

Compound 3, concentration for total growth inhibition: > 32500 nM
Compound 3: no number, only a limit (the forecaster's own chance of this, stated with the estimate: 10%); middle value at least 13-fold (1.11 log units) from the limit.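

Measured in this assay, compound 3 gives only a limit of the assay and not a number: the limit of > 32500 nM in this assay, at which 1 of the 3 values shown sits.

Even so, the steps can be read as minimum sizes: an at least 17-fold higher number from compound 2 to compound 3 (1.24 log units; beyond the scatter), and an at least 5.0-fold higher number from compound 1 to compound 3 (0.70 log units; beyond the scatter). The earlier step changed only the aryl group on the urea and kept the amide-type nitrogen on the carbonyl carbon, whereas these two steps show that the series loses much of its growth inhibition when that nitrogen gives way to a directly attached 4-chloro-3-(trifluoromethyl)phenyl.

The compounds shown leave open whether the lost nitrogen, the added chlorine or both account for this, as the two change together. They also leave open whether a methylene group or an oxygen atom in place of that nitrogen would restore the growth inhibition seen with the ureas.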